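One Carbon Added to an Ester Chain: An Expectation

The compounds below may be only part of what the source reports. "The series", "measured", "known", "first", "only" and "open" are said of these compounds alone.

Of the compounds shown here, three have been measured in an assay on membranes from CHO cells for displacement of a labelled ligand from adenosine receptor A1 (Homo sapiens), read by scintillation counting, with a stated time of 60 min, tested at 1 uM; on this read-out higher numbers stand for more inhibition at the one concentration tested (going by the name of the read-out) and lower numbers for less inhibition. Compound 1 `CCCOC(=O)C1=C(C)NC(=O)NC1c1cccs1` gives 43%, compound 2 `CC1=C(C(=O)OCC(C)C)C(c2cccs2)NC(=O)N1` gives 25%, and compound 3 `CCOC(=O)C1=C(C)N(C)C(=O)NC1c1cccs1` gives 1%, the lowest of the three. Compound 2 arises from compound 1 by methyl in place of hydrogen on a saturated chain carbon bound to two saturated chain carbons and this brought a number 18 percentage points lower from compound 1 to compound 2 (beyond the scatter). Compound 4 `CCCOC(=O)C1=C(C)N(C)C(=O)NC1c1cccs1` has not yet been measured; it differs from compound 3 by methyl in place of hydrogen on a saturated chain carbon, two bonds along the chain from an oxygen next to a carbonyl group. The two changes are the same kind of change, a methyl entering for a hydrogen on a saturated chain carbon, but the surroundings differ: in compound 2 that carbon is bound to two saturated chain carbons, whereas in compound 4 it is two bonds along the chain from an oxygen next to a carbonyl group. The cores of compound 1 and compound 3 also differ, and that difference is not broken down here. Because compound 3 gives 1% and the earlier change gave a number 18 percentage points lower from compound 1 to compound 2 (beyond the scatter), the step expected in this assay is small, a number 4 percentage points higher from compound 3 to compound 4 (within the scatter). Compound 4 is therefore expected to give 5%, estimated between 0% and 20%.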

Compound 4, a percentage reported as inhibition, at one concentration (the size of the read-out at that concentration, not a potency): 9%
For compound 4 the middle estimate is 4 percentage points below the measured one, within the range that was stated.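

The methyl added to the ester chain does not behave alike on the two cores in this assay: the same change on two cores in this assay, a number 18 percentage points lower (beyond the scatter) from compound 1 to compound 2 and a number 8 percentage points higher (within the scatter) from compound 3 to compound 4, 26 percentage points apart, beyond the scatter of two such steps. On the core whose ring nitrogen carries a methyl, the change from ethoxy to propoxy gives a number 8 percentage points higher from compound 3 to compound 4 (within the scatter), whereas methyl in place of hydrogen on an amide-type nitrogen in a ring, with the propyl ester kept, gives a number 34 percentage points lower from compound 1 to compound 4 (beyond the scatter). This shows that, in this one pair of cores, the step seen on the first core could not be carried over to the second, but it rests on just two steps read at a single concentration, so it gives no rule for other cores and no reason for the difference.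

The compounds shown leave open how a longer chain on the ester, such as butyl, or a carboxylic acid in place of the ester would read on either core. Going by these compounds, how the branched ester of compound 2 would read with a methyl on the ring nitrogen also stays open.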